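Removing a Methyl From an Aryl Ether: Expected Cytotoxicity

This account rests on a few compounds, and the source may have more. Where it says the series, first, only, none or still open, it means among the compounds named here.

Measured compounds:
compound 1, `Cc1cc(O)cc(-c2nn(CC#N)cc2-c2ccnc(-c3ccc(Oc4ccccc4)cc3)c2)c1`, gives 103% in a functional assay on OVCAR-3 cells (Homo sapiens) for cytotoxicity, read by sulforhodamine B assay, with a stated time of 48 h, tested at 0.01 uM; a lower number here means a stronger effect, a higher number a weaker effect of the compound at the concentration tested
compound 2, `COc1cc(C)cc(-c2nn(CC#N)cc2-c2ccnc(-c3ccc(N(C)C)cc3)c2)c1`, gives 95% in this assay

The two readings sit close together: the number for compound 2 lies within the usual scatter of the number for compound 1, so the two compounds cannot be told apart, and neither shows a strong effect at the concentration tested.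

Compound 3, `Cc1cc(O)cc(-c2nn(CC#N)cc2-c2ccnc(-c3ccc(N(C)C)cc3)c2)c1`, has not yet been measured. It arises from compound 2 through a single change: hydrogen in place of methyl on an oxygen on an aromatic ring. Compound 1 already carries the hydroxy group on that ring, though with a different group elsewhere, and its reading matches that of compound 2, so the change gives no hint of a shift. Among the measured compounds shown here, no step between measured compounds is available to size it. In this assay I expect no step beyond the scatter, in either direction. Compound 3 is therefore expected to give 98%, with a range from 86% to 110%. The expected step of a number 3 percentage points higher from compound 2 to compound 3 (within the scatter) is small.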

Compound 3, a percentage reported as activity, at one concentration (the size of the read-out at that concentration, not a potency): 91%
For compound 3 the middle estimate is 7 percentage points above the measured one; low and high end bracket the measured number.
By their numbers in this assay, from the lowest: compounds 3, 2 and 1 (each within the scatter of the next, the first and the last beyond it).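

Swapping methoxy for hydroxy on the 3-methoxy-5-methylphenyl ring gives a number 4 percentage points lower from compound 2 to compound 3 (within the scatter) in this assay, so at this position the two groups cannot be told apart. Among the compounds shown here, the hydroxy compounds also give the first step beyond the scatter: with dimethylamino in place of phenoxy on an aromatic carbon, the reading moves by a number 12 percentage points lower from compound 1 to compound 3 (beyond the scatter), a modest change at the far end of the molecule. Even so, compound 3 gives 91%, which is far from a strong effect at the concentration tested. Nothing at hand explains either step.

As far as these compounds go, whether an ethoxy group or an amine at the same place on that ring would read any differently stays open. So does whether the dimethylamino for phenoxy step would keep its size with methoxy on the ring instead of hydroxy.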